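This account rests on a few compounds, and the source may have more. Where it says the series, first, only, none or still open, it means among the compounds named here.

Measured compounds in an assay on CHO cells for displacement of a labelled ligand from adenosine receptor A1 (Homo sapiens), read by scintillation counting, with a stated time of 90 min, in the presence of a further agent that is not named here; on this read-out lower numbers stand for stronger inhibition and higher numbers for weaker inhibition:
Compound 1, `CCCn1c(=O)[nH]c2nc(-c3ccc(S(=O)(=O)N4CCN(c5cccc(Cl)c5)CC4)cc3)[nH]c2c1=O`, is reported only as a limit, > 1000 nM.
Compound 2, `CCCn1c(=O)[nH]c2nc(-c3ccc(S(=O)(=O)N4CCN(Cc5cccc(Br)c5)CC4)cc3)[nH]c2c1=O`, gives 928 nM.
Compound 3, `CCCn1c(=O)[nH]c2nc(-c3ccc(S(=O)(=O)N4CCN(c5ccccc5)C(C)C4)cc3)[nH]c2c1=O`, is reported only as a limit, > 1000 nM.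

Compound 3 therefore stands at the limit of this assay, not at a number; two of the three values shown sit at that limit (the limit of > 1000 nM in this assay, at which 2 of the 3 values shown sit). Compound 3 and compound 1 both carry that limit, so no order between them can be read. Among the compounds with values here, compound 2 is the only compound with a number, and the single measured step, an at least 1.0-fold lower number from compound 1 to compound 2 (0.03 log units; that floor lies within the scatter), lies within the scatter.

Compound 4, `CCCn1c(=O)[nH]c2nc(-c3ccc(S(=O)(=O)N4CCN(c5ccccc5)CC4)cc3)[nH]c2c1=O`, differs from compound 3 by hydrogen in place of methyl on a saturated ring carbon. No measured step touches this saturated ring carbon; the one step shown concerns the group on the amine nitrogen of the ring and was within the scatter. Every value in the series sits at or close to the limit, so no step beyond the scatter is expected from compound 3 to compound 4, and the estimated step that the limit leaves unreadable from compound 3 to compound 4 is taken as close to nothing. Compound 4 is expected to give about 1500 nM, within 500 nM to 5000 nM, with a substantial chance that only a limit is reported.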

Compound 4, inhibition constant: 364 nM
Beside the measured number, compound 4's estimate is 4.1-fold (0.61 log units) above it; the whole stated range lies above it.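

In this assay, within the data shown here, hydrogen in place of methyl on a saturated ring carbon gives an at least 2.7-fold lower number from compound 3 to compound 4 (0.43 log units; beyond the scatter), so this position, which no earlier step touched, responds to the loss of a single methyl. The phenyl on the ring nitrogen of compound 4 also separates from the other two compounds, with a 2.5-fold lower number from compound 2 to compound 4 (0.41 log units; beyond the scatter) for phenyl in place of 3-bromobenzyl and an at least 2.7-fold lower number from compound 1 to compound 4 (0.43 log units; beyond the scatter) for hydrogen in place of chloro on an aromatic carbon. Two of these three steps give only a floor and not a size, because compound 1 and compound 3 are each reported as a limit: the limit of > 1000 nM in this assay, at which 2 of the 4 values shown sit.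

The compounds shown leave open whether an ethyl or a hydroxymethyl on this saturated ring carbon behaves as the methyl does, and how large the step from the methyl really is. They also leave open whether a fluoro or a methoxy in place of the chloro follows compound 1, and whether an unsubstituted benzyl on the ring nitrogen stands with compound 2 or with compound 4.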